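A few compounds are considered here, and "the series" means these few. Any claim that something is new, unique, unknown or untested is made for them only; others in the source may bear on it.

The measured compounds:

Compound 1, `Fc1ccc(Nc2cc3[nH]c(Nc4ccc(N5CCN(CC6CC6)CC5)cn4)nc3cn2)cc1C(F)(F)F`, gives 41000 nM in an ADME assay on CHO cells (Cricetulus griseus) for cytotoxicity, read by MTT assay; a lower number here means that less compound is tolerated, a higher number that more compound is tolerated.
Compound 2, `Fc1ccc(Nc2cc3[nH]c(Nc4ccc(N5CCN(CC6CC6)CC5)cn4)nc3cn2)cc1F`, gives 1200 nM in this assay.
Compound 3, `O=C(c1ccnc(Nc2nc3cnc(Nc4ccc(F)c(C(F)(F)F)c4)cc3[nH]2)c1)N1CCN(C2CC2)CC1`, gives 30000 nM in this assay.

Compound 4, `O=C(c1ccnc(Nc2nc3cnc(Nc4ccc(F)c(F)c4)cc3[nH]2)c1)N1CCN(C2CC2)CC1`, has not yet been measured in this assay. It comes from compound 3 by one change: fluoro in place of trifluoromethyl on an aromatic carbon. The same change turns compound 1 into compound 2: fluoro in place of trifluoromethyl on an aromatic carbon. The surroundings of the changed place read the same in both pairs, so the two changes are the same. How the core of compound 3 differs from the core of compound 1 is not broken down here. In this assay the change made a 34-fold lower number from compound 1 to compound 2 (1.53 log units; beyond the scatter), a step beyond the usual scatter. Compound 3 and compound 1 give numbers within the scatter of each other, so the two starting points are alike. Among the compounds with values here, for compound 4 the expected step is a 20-fold lower number from compound 3 to compound 4 (1.30 log units; beyond the scatter), resting on the one measured example, a 34-fold lower number from compound 1 to compound 2 (1.53 log units; beyond the scatter), with some room left in case the different core of compound 3 softens the effect. Compound 4 is thus estimated at 1500 nM, between 400 nM and 8000 nM.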

Compound 4, half-maximal cytotoxic concentration in the CHO assay: > 50000 nM
Compound 4 ended at the assay's limit (the forecaster's own chance of this, stated with the estimate: 5%); middle value at least 33-fold (1.52 log units) away from the limit.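

In the CHO assay compound 4 gives > 50000 nM, which is a limit of the assay and not a number. On the core of compound 3, fluoro in place of trifluoromethyl gave an at least 1.6-fold higher number from compound 3 to compound 4 (0.22 log units; that floor lies within the scatter), so the large drop seen on the core of compound 1 did not carry over, and the two steps differ: the same change on two cores in the CHO assay, a 34-fold lower number (1.53 log units; beyond the scatter) from compound 1 to compound 2 and an at least 1.6-fold higher number (0.22 log units; that floor lies within the scatter) from compound 3 to compound 4, at least 56-fold (1.75 log units) apart, beyond the scatter of two such steps. Going by these compounds, the outcome of this change therefore depended on the core in these two pairs, but one pair per core gives no general rule for other cores, and the true size of the new step stays unknown: the limit of > 50000 nM in the CHO assay, at which 1 of the 4 values shown sits.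

In a physicochemical assay for solubility, read by HPLC, using the shake flask method, in phosphate buffer, measured as kinetic solubility, with a stated time of 20 h, at pH 6.5 (on this read-out higher numbers stand for higher solubility and lower numbers for lower solubility), compound 3 gives < 5000 nM, which is a limit of the assay and not a number. In the physicochemical assay compound 4 gives < 5000 nM, which is also a limit of the assay and not a number. Both compounds sit at a limit, so that step cannot be read: the limit of < 5000 nM in the physicochemical assay, at which 2 of the 2 values shown sit. Still open, on these data alone, is which part of the core of compound 3 separates it from the core of compound 1, and how a chloro or methoxy group in place of the trifluoromethyl would behave on each core.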